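The compounds below may be only part of what the source reports. "The series", "measured", "known", "first", "only" and "open" are said of these compounds alone.

Working notes on the series. In a functional assay on HeLa cells (Homo sapiens) for cytotoxicity, read by MTT assay, with a stated time of 48 h (a lower number here means a stronger inhibitor, a higher number a weaker inhibitor), compound 1 (`Cc1ccc(C)c(/C=C/[C@](C)(O)CC[C@@H]2[C@@]3(C)CCCC(C)(C)[C@@H]3CC[C@@]2(C)O)c1`) gives 3380 nM, and compound 2 (`Cc1cccc(C)c1/C=C/[C@](C)(O)CC[C@@H]1[C@@]2(C)CCCC(C)(C)[C@@H]2CC[C@@]1(C)O`) gives 3460 nM. For the measured compounds named here, compound 2 therefore stands level with compound 1, the only other measured compound, and the two numbers lie within the scatter of each other.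

The next compound is compound 3 (`CC1(C)CCC[C@]2(C)[C@@H](CC[C@@](C)(O)/C=C/c3ccc(Br)cc3)[C@](C)(O)CC[C@@H]12`), with 4-bromophenyl in place of 2,6-dimethylphenyl on a double-bonded chain carbon bound to a double-bonded chain carbon.

Going by the values given here, only one measured step bears on this change: a 1.0-fold higher number from compound 1 to compound 2 (0.01 log units; within the scatter). That step exchanges 2,5-dimethylphenyl for 2,6-dimethylphenyl at the same place and stays within the scatter. Among the compounds with values here, it is weak evidence, since both of its compounds carry dimethylphenyl groups and no measured compound carries 4-bromophenyl. On these data alone, the data therefore favour no direction, and any real shift in this assay remains open.

The expected change is a 1.1-fold lower number from compound 2 to compound 3 (0.03 log units; within the scatter), which means no step beyond the scatter is expected. For compound 3 the estimated value is 3200 nM, with an expected range of 1400 nM to 7500 nM.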

Compound 3, half-maximal inhibitory concentration: 45900 nM
Beside the measured number, compound 3's estimate is 14-fold (1.16 log units) below it; measured number outside the range, above it.
By their numbers in this assay, from the lowest: compounds 1 and 2 (each within the scatter of the next); then compound 3.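

In this assay the place on a double-bonded chain carbon bound to a double-bonded chain carbon proves sensitive to the aromatic group it carries: 4-bromophenyl in place of 2,6-dimethylphenyl gives a 13-fold higher number from compound 2 to compound 3 (1.12 log units; beyond the scatter) and 4-bromophenyl in place of 2,5-dimethylphenyl gives a 14-fold higher number from compound 1 to compound 3 (1.13 log units; beyond the scatter) on the same core. The two dimethylphenyl groups lie within the scatter of each other, so the tolerance seen in the earlier pair holds only for that exchange and does not extend to 4-bromophenyl, which gives the weakest compound of the three, with both of its steps beyond the scatter. Nothing at hand accounts for the size of this change in either step.

The three compounds leave open whether the weaker number follows the bromine itself or the loss of the two methyl groups, as 4-bromophenyl differs from both dimethylphenyl groups in both respects. A plain phenyl, a 4-methylphenyl or a 4-chlorophenyl group at this place, or a ring carrying an amine, would be needed to separate these readings.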